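From Propylcarbonyl to Carbamoyl: an Expected Loss of Potency

The source may report more compounds than this note shows. Statements on the series, on what has been measured and on what is new or still open speak of the compounds shown alone.

Among the measured compounds shown here, compound 2 `CCCC(=O)C1=Cc2ccc(OC)cc2OC1c1cc(OC)c(OC)c(OC)c1` gives 11700 nM in a functional assay for inhibition of nuclear factor NF-kappa-B complex (Homo sapiens) (on this read-out higher numbers stand for weaker inhibition and lower numbers for stronger inhibition), the only real number among the two values at hand. Compound 1 `COc1ccc2c(c1)OC(c1cc(OC)c(OC)c(OC)c1)C(CO)=C2` reaches only a limit of this assay, > 50000 nM. For the measured compounds named here, the single measured step, an at least 4.2-fold lower number from compound 1 to compound 2 (0.63 log units; beyond the scatter), is known only as a floor because of the limit of > 50000 nM in this assay, at which 1 of the 2 values shown sits. Compound 3 `COc1ccc2c(c1)OC(c1cc(OC)c(OC)c(OC)c1)C(C(N)=O)=C2` differs from compound 2 by amino in place of propyl on a carbonyl carbon. Since the entering amino brings 1 hydrogen-bond donor while the step toward the ketone had helped, the step is expected to be a 2.6-fold higher number from compound 2 to compound 3 (0.41 log units; beyond the scatter). Compound 3 is therefore estimated at 30000 nM, between 10000 nM and 90000 nM.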

Compound 3, half-maximal inhibitory concentration: > 50000 nM
Compound 3: a limit, no number (the forecaster's own chance of this, stated with the estimate: 40%); middle value at least 1.6-fold (0.22 log units) away from the limit.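

Amino in place of propyl on the carbonyl carbon gives an at least 4.2-fold higher number from compound 2 to compound 3 (0.63 log units; beyond the scatter) in this assay, so a carbonyl at this position does not by itself keep the activity of compound 2. Compound 3 stands at a limit, > 50000 nM, not a number. That step is therefore only a floor, and the step from compound 1 to compound 3 cannot be read, because both compounds sit at this limit: the limit of > 50000 nM in this assay, at which 2 of the 3 values shown sit.

The compounds shown leave open whether a butyl chain or a phenyl group on the same carbonyl carbon would lower the number further than propyl does.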